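The source may hold more compounds than are shown below. What is called first, only, known or untested is meant among the compounds shown, and "the series" means these compounds.

Of the compounds shown here, three have been measured so far: compound 3 `CC/N=C(/NC#N)NCCCn1nc(-c2ccccc2)ccc1=O`, compound 2 `CC/N=C(/NC#N)NCCCCn1nc(-c2ccccc2)ccc1=O` and compound 1 `CC/N=C(/NC#N)NCCCn1nc(-c2ccccc2)cc(C)c1=O`. In a functional assay on the whole organism with Rattus norvegicus as the target, at a dose of 100 mg/kg (on this read-out higher numbers stand for more inhibition at the one dose given (going by the name of the read-out) and lower numbers for less inhibition), compound 3 gives 62.9%. In this assay compound 2 gives 58.8%, and compound 1 gives 23.5%. The values of compound 2 and compound 3 lie within the scatter of each other. Compound 1 arises from compound 3 through a single change, (methyl in place of hydrogen on an aromatic carbon), and that change produced the step of a number 39.4 percentage points lower from compound 3 to compound 1 (beyond the scatter). How the core of compound 2 differs from the core of compound 3 is not broken down here.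

Compound 4 `CC/N=C(/NC#N)NCCCCn1nc(-c2ccccc2)cc(C)c1=O` is the yet unmeasured compound. It arises from compound 2 through the same change, (methyl in place of hydrogen on an aromatic carbon), made at a place described in exactly the same words as for compound 1. Because the step of a number 39.4 percentage points lower from compound 3 to compound 1 (beyond the scatter) was large, a step of similar size is expected here, namely a number 38.8 percentage points lower from compound 2 to compound 4 (beyond the scatter). On that basis compound 4 is expected to give 20% in this assay, most likely between 5% and 40%.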

Compound 4, a percentage reported as inhibition, in the whole organism at one dose (the size of the read-out at that dose, not a potency): 42.5%
The estimate for compound 4 lay 22.5 percentage points below the measured number, and the stated range ends below it.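

Placing a methyl in place of hydrogen on the aromatic carbon lowers the number on both cores, and on the second core in this assay it gives a number 16.3 percentage points lower from compound 2 to compound 4 (beyond the scatter), so the direction of the change carried over in these two pairs. The size of the step did not carry over, and a step measured on one core therefore cannot simply be copied to the other: the same change on two cores in this assay, a number 39.4 percentage points lower (beyond the scatter) from compound 3 to compound 1 and a number 16.3 percentage points lower (beyond the scatter) from compound 2 to compound 4, 23.1 percentage points apart, beyond the scatter of two such steps

These two pairs do not show why the steps differ, or whether a third core would follow either of them, and each number describes the response at one dose rather than a potency.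

The compounds shown leave open how the same methyl change would behave on a core with a longer chain than that of compound 2. They also leave open whether an ethyl group, an amine or a carboxylic acid on that same aromatic carbon would lower the number as the methyl does.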